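Shrinking the Aryl Substituent from Cyclohexyl to Bromine

This account rests on a few compounds, and the source may have more. Where it says the series, first, only, none or still open, it means among the compounds named here.

Compound 3 `Clc1ccc(CO/N=C/c2c(-c3ccc(C4CCCCC4)cc3)nc3sccn23)cc1Cl` carries a cyclohexyl group on one of its aromatic rings. In an assay on HepG2 cells for agonist activity at nuclear receptor subfamily 1 group I member 3 (Homo sapiens), read by a luciferase reporter, with a stated time of 23 h (a higher number here means that more compound is needed for the effect, a lower number that less compound is needed), compound 3 reaches only the limit of the assay, > 100000 nM, so no true number is known for it. Compound 1 `Cc1ccc(-c2nc3sccn3c2/C=N/OCc2ccc(Cl)c(Cl)c2)cc1`, which carries a methyl group instead, gives 490 nM. Going by the values given here, the one measured step that bears on the present change is an at least 200-fold higher number from compound 1 to compound 3 (2.30 log units; beyond the scatter), and compound 2 `Clc1ccc(CO/N=C/c2c(-c3ccc(-c4ccccc4)cc3)nc3sccn23)cc1Cl` is reported as "not active" (no number reported). Compound 4 `Clc1ccc(CO/N=C/c2c(-c3ccc(Br)cc3)nc3sccn23)cc1Cl` differs from compound 3 as follows: bromo in place of cyclohexyl on an aromatic carbon. Since the small methyl of compound 1 gave 490 nM, a small bromo is expected to recover much of that potency. Compound 4 is therefore expected to show a large drop, an at least 100-fold lower number from compound 3 to compound 4 (2.00 log units; beyond the scatter), to an estimated 1000 nM, between 200 nM and 20000 nM.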

Compound 4, half-maximal effective concentration: 480 nM
Beside the measured number, compound 4's estimate is 2.1-fold (0.32 log units) above it, and the stated range covers the measured number.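

Replacing cyclohexyl with bromo gives an at least 200-fold lower number from compound 3 to compound 4 (2.31 log units; beyond the scatter), so this position clearly tolerates bromo as well as methyl. The two groups cannot be told apart in this assay, with a 1.0-fold lower number from compound 1 to compound 4 (0.01 log units; within the scatter). Going by these compounds, compound 3 stands at a limit, so the true size of its step to bromo is unknown: the limit of > 100000 nM in this assay, at which 1 of the 4 values shown sits.

On these data alone, whether an amine or a methoxy group at this position would keep the response remains open. So does the question of how long an alkyl chain can grow here before the response falls away.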